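Aryl for Cyclohexyl on the Oxadiazole of Compound 3

The compounds below may be only part of what the source reports. "The series", "measured", "known", "first", "only" and "open" are said of these compounds alone.

Compound 1 `Fc1ccc(-c2noc(C3CCc4c(nnn4-c4ccc(F)cc4)C3)n2)cc1`: 15.9 nM
Compound 2 `CC(C)Cc1noc(C2CCc3c(nnn3C(C)(C)C)C2)n1`: 1000 nM
Compound 3 `CC(C)(C)n1nnc2c1CCC(c1nc(C3CCCCC3)no1)C2`: 200 nM

In a functional assay on U2OS cells for positive allosteric modulation of metabotropic glutamate receptor 5 (Homo sapiens), read by calcium flux, in the presence of a further agent that is not named here (a higher number here means that more compound is needed for the effect, a lower number that less compound is needed), compound 3 gives 200 nM, the second highest of the three numbers; compound 2 sits above it and compound 1 well below. The step from compound 3 to compound 4 `CN(C)c1ccc(-c2noc(C3CCc4c(nnn4C(C)(C)C)C3)n2)cc1` is 4-(dimethylamino)phenyl in place of cyclohexyl on an aromatic carbon. Among the measured compounds shown here, the only measured step at that position is a 5.0-fold lower number from compound 2 to compound 3 (0.70 log units; beyond the scatter), which concerns two saturated groups and says nothing direct about an aromatic ring entering there. Compound 1, which carries an aromatic ring at this place but differs from compound 3 elsewhere too, gives the lowest number of the set. For compound 4 a step of a 2.9-fold lower number from compound 3 to compound 4 (0.46 log units; beyond the scatter) in this assay is therefore expected, with an estimated value of 70 nM and a range of 20 nM to 250 nM.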

Compound 4, half-maximal effective concentration: 1000 nM
Compound 4: middle estimate off by 14-fold (1.15 log units), on the low side; measured number above the stated range.
By their numbers in this assay, from the lowest: compound 1; then compound 3; then compounds 2 and 4 (each within the scatter of the next).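

In this assay 4-(dimethylamino)phenyl in place of cyclohexyl brings a 5.0-fold higher number from compound 3 to compound 4 (0.70 log units; beyond the scatter) and so shows that an aromatic ring at this place does not by itself lower the number. Set against isobutyl the same group shows no change at the digits printed from compound 2 to compound 4 (within the scatter) and the lower number reached with cyclohexyl is not kept. Of the three groups on this shared core, only cyclohexyl gives the lower number.

As far as these compounds go, whether a plain phenyl or a cyclopentyl at this place would keep that lower number stays open. No measurement at hand accounts for this result.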